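Adding a propoxy group to the ring of compound 2

The source may hold more compounds than are shown below. What is called first, only, known or untested is meant among the compounds shown, and "the series" means these compounds.

Measured compounds in a functional assay on the whole organism with Mus musculus as the target, in the maximal electroshock model, at a dose of 50 mg/kg by the oral route; on this read-out lower numbers stand for less inhibition and higher numbers for more inhibition at the one dose given (going by the name of the read-out):
compound 1, `CN(C)CCCOc1ccccc1/C=C/c1ccccc1`: 14.2%
compound 2, `C(=C/c1ccccc1OCCCCN1CCCCC1)\c1ccccc1`: 42.9%
compound 3, `CN(C)CCN(C)CCCCOc1ccccc1/C=C/c1ccccc1`: 0%

Compound 2 stands highest of the three numbers in this assay; the nearest is compound 1, and the furthest is compound 3. Both steps leading away from compound 2 alter the amine at the end of the chain: a number 28.7 percentage points higher from compound 1 to compound 2 (beyond the scatter) and a number 42.9 percentage points lower from compound 2 to compound 3 (beyond the scatter), so this end of the molecule is where the read-out has moved most. Compound 4, `CCCOC1CCCN(CCCCOc2ccccc2/C=C/c2ccccc2)C1`, keeps the whole of compound 2 and changes it in one place: propoxy in place of hydrogen on a saturated ring carbon. Among the measured compounds shown here, no measured step touches a ring carbon of the piperidin-1-yl group, so neither step is a direct guide; they only show that changes at this end can move the number by modest to large amounts in either direction. Compound 4 is therefore expected to stay near compound 2, with a wide range: 38% (from 12% to 62%), which means an expected step of a number 4.9 percentage points lower from compound 2 to compound 4 (within the scatter).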

Compound 4, a percentage reported as inhibition, in the whole organism at one dose (the size of the read-out at that dose, not a potency): 0%
The estimate for compound 4 lay 38 percentage points above the measured number, and the stated range ends above it.
By their numbers in this assay, from the lowest: compounds 3 and 4 (each within the scatter of the next); then compound 1; then compound 2.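

In this assay, putting propoxy on a saturated ring carbon, two ring bonds from the ring nitrogen, gives a number 42.9 percentage points lower from compound 2 to compound 4 (beyond the scatter) and so removes the whole of the inhibition seen for compound 2 at the one dose given. The earlier steps shown here replaced the amine itself, whereas this one keeps the piperidin-1-yl ring and shows that a single substituent on one of its carbons is enough to move the read-out by a large amount. No measurement at hand speaks to the cause of this step.

As far as these compounds go, whether a smaller group such as methoxy or hydroxy at the same ring carbon would keep the inhibition of compound 2 remains open. A propyl group there would also be needed to tell whether the ring oxygen of the ether link matters, or the carbon chain alone.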